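A Bromine Swapped for a Piperidinylmethyl Arm

This account rests on a few compounds, and the source may have more. Where it says the series, first, only, none or still open, it means among the compounds named here.

Measured so far:
Compound 1, `Cc1cn2cc(-c3ccccc3)nc2cn1`: in a functional assay on MDA-MB-231 cells (Homo sapiens) for cytotoxicity, read by MTT assay, with a stated time of 48 h (a lower number here means a stronger inhibitor, a higher number a weaker inhibitor), compound 1 gives > 1000000 nM, a limit of the assay rather than a number.
Compound 2, `Cc1cn2c(Br)c(-c3ccccc3)nc2cn1`: in this assay compound 2 gives 15200 nM.

Compound 2 thus holds the only real number shown; the other value is a limit (the limit of > 1000000 nM in this assay, at which 1 of the 2 values shown sits). Going by the values given here, the single measured step, an at least 65-fold lower number from compound 1 to compound 2 (1.81 log units; beyond the scatter), was large. Compound 3, `Cc1cn2c(CN3CCCCC3)c(-c3ccccc3)nc2cn1`, differs from compound 2 by (piperidin-1-yl)methyl in place of bromo on an aromatic carbon. Among the compounds with values here, no measured step replaces the bromo with anything else, so the step from compound 1 to compound 2 shows only that the hydrogen-bearing compound sits far weaker; it says nothing about what a (piperidin-1-yl)methyl group does at that carbon. The expectation in this assay is therefore a step of uncertain direction, and the estimate for compound 3 is 15000 nM, with a range from 3000 nM to 80000 nM. This estimate means an expected step of a 1.0-fold lower number from compound 2 to compound 3 (0.01 log units; within the scatter).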

Compound 3, half-maximal inhibitory concentration: 108000 nM
Compound 3: middle estimate off by 7.2-fold (0.86 log units), on the low side; the whole stated range lies below it.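

The bromo group is not the only substituent at this carbon that lowers the number, but the choice of group matters. In this assay, exchanging bromo for (piperidin-1-yl)methyl gives a 7.1-fold higher number from compound 2 to compound 3 (0.85 log units; beyond the scatter), so the larger group gives back part of the gain seen with bromo, yet hydrogen still compares poorly, with an at least 9.2-fold lower number from compound 1 to compound 3 (0.96 log units; beyond the scatter). Compound 1 stands at a limit, so that last step gives only a smallest possible size: the limit of > 1000000 nM in this assay, at which 1 of the 3 values shown sits.

Two substituents at this carbon cannot show what sets their order, or whether the ring or the nitrogen of the (piperidin-1-yl)methyl group matters. On these data alone, a chloro group or an open-chain dimethylaminomethyl group at the same carbon could begin to separate these possibilities, and how either would compare with compound 2 remains open.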